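The source may report more compounds than this note shows. Statements on the series, on what has been measured and on what is new or still open speak of the compounds shown alone.

Compound 3, with the structure `Cc1ccc(CN2C(=O)S/C(=C\c3cccc(N)c3)C2=O)cc1`, gives no number in a functional assay on CCRF-CEM cells (Homo sapiens) for cytotoxicity, read by cell counting, with a stated time of 3 days; a lower number here means a stronger inhibitor, a higher number a weaker inhibitor; it reaches only the limit of the measurement, > 250000 nM. Its relatives do give numbers. Compound 1, `Nc1cccc(/C=C2\SC(=O)N(Cc3ccc(F)cc3)C2=O)c1`, carries a 4-fluorophenyl group on the same carbon and gives 87000 nM in this assay. Compound 2, `Nc1cccc(/C=C2\SC(=O)N(Cc3cccc(Cl)c3)C2=O)c1`, carries a 3-chlorophenyl there and gives 195000 nM in this assay. Compound 4, `Nc1cccc(/C=C2\SC(=O)N(Cc3cccc(F)c3)C2=O)c1`, is not yet measured; it differs from compound 3 by 3-fluorophenyl in place of 4-methylphenyl on a saturated chain carbon bound to an amide-type nitrogen in a ring.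

Going by the values given here, three measured steps bear on this change. Going from the fluoro of compound 1 to the methyl of compound 3 gives an at least 2.8-fold higher number from compound 1 to compound 3 (0.45 log units; beyond the scatter), and the shift from compound 2 to compound 3 gives an at least 1.2-fold higher number from compound 2 to compound 3 (0.10 log units; that floor lies within the scatter), both pointing away from the limit. Moving a halogen around the ring, as in a 2.2-fold higher number from compound 1 to compound 2 (0.35 log units; beyond the scatter), changes little. Since compound 4 takes the fluorophenyl theme of compound 1 and the ring position of compound 2, the expected step in this assay is downward, back from the limit to a measurable number, an at least 1.9-fold lower number from compound 3 to compound 4 (0.28 log units; that floor lies within the scatter). The estimate for compound 4 is therefore 130000 nM, with a range from 60000 nM to 250000 nM.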

Compound 4, half-maximal inhibitory concentration: 250000 nM
Beside the measured number, compound 4's estimate is 1.9-fold (0.28 log units) below it; the range from low to high includes it.
By their numbers in this assay, from the lowest: compound 1; then compounds 2 and 4 (each within the scatter of the next).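

Moving the fluorine, with 3-fluorophenyl in place of 4-fluorophenyl, gives a 2.9-fold higher number from compound 1 to compound 4 (0.46 log units; beyond the scatter) in this assay, so where the fluorine sits on this phenyl ring changes the number, which no earlier pair could show with the halogen held the same. Fluoro in place of chloro on an aromatic carbon gives a 1.3-fold higher number from compound 2 to compound 4 (0.11 log units; within the scatter), so the 3-fluorophenyl and 3-chlorophenyl groups are not told apart here, and among the compounds with numbers only compound 1 stands apart. 3-Fluorophenyl in place of 4-methylphenyl gives a number no higher from compound 3 to compound 4 (the limit leaves the size open) and the size of this step cannot be read because one end of it is a limit and not a number: the limit of > 250000 nM in this assay, at which 1 of the 4 values shown sits.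

Compound 1, at 87000 nM, has the lowest number shown, and it stays open whether an amine or a carboxylic acid on the phenyl ring, or a longer chain in place of the saturated chain carbon, would bring the number lower. Going by these compounds, it is also open whether moving chloro or methyl around the phenyl ring would change the number as moving the fluorine does.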